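The compounds below may be only part of what the source reports. "The series", "measured", "known", "first", "only" and "open" are said of these compounds alone.

Of the compounds shown here, three have been measured. Compound 1 `CC1=CC[C@H](C(C)(C)NC(=S)NN)CC1` is the smallest of them; in a functional assay on HT-29 cells (Homo sapiens) for inhibition, read by sulforhodamine B assay, with a stated time of 48 h (on this read-out lower numbers stand for stronger inhibition of growth and higher numbers for weaker inhibition of growth), compound 1 gives 60100 nM. Compound 2 `COc1ccc(/C=N/NC(=S)NC(C)(C)[C@H]2CC=C(C)CC2)cc1` carries a methoxyphenyl group on the carbon double-bonded to nitrogen, and in this assay compound 2 gives 8400 nM. Compound 3 `CC1=CC[C@H](C(C)(C)NC(=S)N/N=C/c2ccc(F)cc2)CC1` differs from compound 2 only by fluoro in place of methoxy on the aromatic carbon. In this assay compound 3 reaches only a limit of the assay, > 100000 nM. That change brought an at least 11-fold higher number from compound 2 to compound 3 (1.07 log units; beyond the scatter), so compound 3 stands at the weak end of what has been recorded, at the limit of > 100000 nM in this assay, at which 1 of the 3 values shown sits.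

Compound 4 `CC1=CC[C@H](C(C)(C)NC(=S)N/N=C/c2ccco2)CC1` is not yet measured. It differs from compound 3 by furan-2-yl in place of 4-fluorophenyl on a carbon with a double bond to nitrogen. Going by the values given here, no measured step swaps one aromatic ring for another; the only step touching this position, from compound 2 to compound 3, was large. Since compound 3 is only a limit, any direction is possible. Compound 4 is expected near the value of compound 1, 60100 nM, giving an estimated 50000 nM, between 12000 nM and 100000 nM, an expected step of an at least 2.0-fold lower number from compound 3 to compound 4 (0.30 log units; that floor lies within the scatter).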

Compound 4, concentration for 50% growth inhibition: 7200 nM
The estimate for compound 4 lay 6.9-fold (0.84 log units) above the measured number; the measured number lies below the stated range.
By their numbers in this assay, from the lowest: compounds 4 and 2 (each within the scatter of the next); then compound 1. At a limit, above all of these: compound 3.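

In this assay, furan-2-yl in place of 4-fluorophenyl gives an at least 13-fold lower number from compound 3 to compound 4 (1.14 log units; beyond the scatter), so the poor result at this place on the carbon with a double bond to nitrogen does not extend to every aromatic ring. Furan-2-yl in place of 4-methoxyphenyl gives a 1.2-fold lower number from compound 2 to compound 4 (0.07 log units; within the scatter), so a five-membered aromatic ring holds the level of the six-membered one, and the group as a whole gives an 8.3-fold lower number from compound 1 to compound 4 (0.92 log units; beyond the scatter). The figure for compound 3 remains a limit of the assay and not a number: the limit of > 100000 nM in this assay, at which 1 of the 4 values shown sits.

Going by these compounds, it stays open whether the weak result belongs to the fluoro group itself, which an unsubstituted phenyl ring would help to settle. On these data alone, it is also open how a thiophen-2-yl ring, or a phenyl ring bearing an amine, would fare at this place.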